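A few compounds are considered here, and "the series" means these few. Any claim that something is new, unique, unknown or untested is made for them only; others in the source may bear on it.

Working notes on the series. The shared core of compound 1 `CO[C@@H]1CC=C2NN(c3ccc([N+](=O)[O-])cc3)C(=O)CC[C@]2(c2ccccc2)O1` carries a 4-nitrophenyl on an amide-type nitrogen in a ring; in a functional assay on SK-BR-3 cells (Homo sapiens) for cytotoxicity, read by sulforhodamine B assay, with a stated time of 48 h (on this read-out lower numbers stand for stronger inhibition and higher numbers for weaker inhibition), compound 1 gives 7700 nM. Compound 2 `CO[C@@H]1CC=C2NN(c3ccccn3)C(=O)CC[C@]2(c2ccccc2)O1` differs from compound 1 by pyridin-2-yl in place of 4-nitrophenyl on an amide-type nitrogen in a ring, and in this assay compound 2 gives 1120 nM. The step is a 6.9-fold lower number from compound 1 to compound 2 (0.84 log units; beyond the scatter).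

Compound 3 `CO[C@@H]1CC=C2N(c3ccc([N+](=O)[O-])cc3)C(=O)C[C@]2(c2ccccc2)O1` rests on a different core, and how the two cores differ is not broken down here. In this assay compound 3 gives 6300 nM, a number that lies within the usual scatter of the value for compound 1, so the two are not told apart.

Compound 4 `CO[C@@H]1CC=C2N(c3ccccn3)C(=O)C[C@]2(c2ccccc2)O1` stands to compound 3 as compound 2 stands to compound 1: the difference is pyridin-2-yl in place of 4-nitrophenyl on an amide-type nitrogen in a ring. It is the same kind of change, not the same one, since the place differs. In compound 1 the nitrogen sits in a seven-membered non-aromatic ring with 2 nitrogen, next to the ring nitrogen, three ring bonds from the ring atom that bears a fused ring and three from the ring atom that bears a phenyl group; in compound 3 it sits in a five-membered non-aromatic ring with 1 nitrogen, two ring bonds from each of those ring atoms.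

Given that the change made a 6.9-fold lower number from compound 1 to compound 2 (0.84 log units; beyond the scatter) in this assay, and that compound 3 starts from 6300 nM, a step of about the same size is expected for compound 4, namely a 5.3-fold lower number from compound 3 to compound 4 (0.72 log units; beyond the scatter), with the range widened because the single measured instance sits on the other core. Compound 4 is estimated at 1200 nM, expected to lie between 400 nM and 4000 nM.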

Compound 4, half-maximal inhibitory concentration: 1100 nM
For compound 4 the middle estimate is 1.1-fold (0.04 log units) above the measured one; low and high end bracket the measured number.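

On the core of compound 3, pyridin-2-yl in place of 4-nitrophenyl on the amide-type nitrogen gives a 5.7-fold lower number from compound 3 to compound 4 (0.76 log units; beyond the scatter) in this assay. Set beside the step on the core of compound 1, the size of the change carries over from one core to the other: the same change on two cores in this assay, a 6.9-fold lower number (0.84 log units; beyond the scatter) from compound 1 to compound 2 and a 5.7-fold lower number (0.76 log units; beyond the scatter) from compound 3 to compound 4, 1.2-fold (0.08 log units) apart, within the scatter of two such steps

This shows that, for this one exchange of groups and in this one assay, the two cores cannot be told apart by the size of the step, so the step measured on one core served as a fair guide to the other. It does not show that the step would hold on any further core or for any other pair of groups, and with only two instances it gives no account of what produces the step.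

As far as these compounds go, what an unsubstituted phenyl, a 4-aminophenyl or a pyridin-4-yl on the same nitrogen would give stays open, and with it how far the step follows the loss of the nitro group and how far the gain of the ring nitrogen. Also open, from the compounds shown here alone, is how either core would respond to an amine or a carboxylic acid in place of the phenyl group, which stays the same in all four compounds.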